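Swapping a Bromo-Methylphenyl Amide for a Small Polar Ring

The source may report more compounds than this note shows. Statements on the series, on what has been measured and on what is new or still open speak of the compounds shown alone.

Measured so far:
- compound 1, `COc1ccc2nc(C)c(NC(=O)C(=O)Nc3cc(C)cc(C)c3)c(O)c2c1`, gives 10000 nM
- compound 2, `COc1ccc2nc(C)cc(OCC(=O)Nc3ccc(Br)c(C)c3)c2c1`, gives < 1000 nM, which is a limit of the assay rather than a number

Of the compounds shown here, two have been measured in a physicochemical assay for solubility, in phosphate buffer, measured as kinetic solubility, with a stated time of 1 h, at pH 7.4; a higher number here means a more soluble compound, a lower number a less soluble compound. Compound 1 gives 10000 nM. Among the measured compounds shown here, compound 2 returns only < 1000 nM, a limit of the assay and not a measured number; it is the one value sitting at the limit of < 1000 nM in this assay, at which 1 of the 2 values shown sits. For the measured compounds named here, compound 2 therefore stands at the lower edge of what the measurement can report, and no step between measured compounds is available to guide the next change.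

Compound 3, `COc1ccc2nc(C)cc(OCC(=O)NC3CONC3=O)c2c1`, differs from compound 2 in one place: a group of 6 heavy atoms (3 carbon, 1 nitrogen, 2 oxygen; one five-membered non-aromatic ring with 2 hetero atoms) in place of a group of 8 heavy atoms (7 carbon, 1 bromine; one six-membered aromatic ring of carbon only), on an amide-type nitrogen. No change of this kind has been measured here, so the size of the step is uncertain, and the direction rests only on the structural change itself. Compound 3 is expected to move upward in this assay by an at least 5.0-fold higher number from compound 2 to compound 3 (0.69 log units; beyond the scatter). Compound 3 is estimated at 5000 nM, within a range from 800 nM to 30000 nM. Compound 2 itself sits at a limit; compound 3 may likewise return only a limit.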

Compound 3, solubility: >= 166000 nM
Compound 3 gave a limit, no number (the forecaster's own chance of this, stated with the estimate: 30%); at least 33-fold (1.52 log units) between middle value and limit.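

On the amide-type nitrogen, replacing the 4-bromo-3-methylphenyl with the five-membered non-aromatic ring with 2 hetero atoms gives, in this assay, an at least 160-fold higher number from compound 2 to compound 3 (2.22 log units; beyond the scatter), which shows that a change at this one place can shift the read-out by a large amount. Compound 2 marks one end of this step, and its value is a limit and not a number: the limit of < 1000 nM in this assay, at which 1 of the 3 values shown sits.
Compound 3 marks the other end, and its value is also a limit and not a number: the limit of >= 166000 nM in this assay, at which 1 of the 3 values shown sits.

The true size of the step stays unknown, and the compounds shown do not separate what the departing 4-bromo-3-methylphenyl contributes from what the entering ring contributes. Also open, from the compounds shown here alone, is whether a simpler group on the same amide-type nitrogen, such as an unsubstituted phenyl or a short chain ending in an amine, would reach a similar read-out, and whether this ring would give a similar step on a core such as that of compound 1.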